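A few compounds are considered here, and "the series" means these few. Any claim that something is new, unique, unknown or untested is made for them only; others in the source may bear on it.

Measured so far:
compound 1 `CCCCc1nc(C)c(CC(=O)OC(C)C)c(=O)n1Cc1ccc(-c2ccccc2-c2noc(=O)[nH]2)cc1` with 17.5%
compound 2 `CCCCc1nc(C)c(CC(=O)OCC(C)C)c(=O)n1Cc1ccc(-c2ccccc2-c2noc(=O)[nH]2)cc1` with 2.4%

In an ADME assay on microsomes from liver (Homo sapiens) for metabolic stability, with a stated time of 30 min (on this read-out higher numbers stand for a more stable compound and lower numbers for a less stable compound), compound 2 gives 2.4%, the lowest of the two numbers; its nearest neighbour is compound 1 with 17.5%. Compound 3 `CCCCc1nc(C)c(CC(=O)OC2CC2)c(=O)n1Cc1ccc(-c2ccccc2-c2noc(=O)[nH]2)cc1` differs from compound 2 by cyclopropyl in place of isobutyl on an oxygen next to a carbonyl group. Going by the values given here, only one measured step bears on this: a number 15.1 percentage points lower from compound 1 to compound 2 (beyond the scatter). Cyclopropyl is closer in size to isopropyl than to isobutyl, so a rise of roughly that order is expected, and the step is estimated to be a number 8.6 percentage points higher from compound 2 to compound 3 (within the scatter), with wide uncertainty. Compound 3 is therefore estimated at 11%, with a range from 2% to 26%.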

Compound 3, percent of the compound remaining: 34.5%
The estimate for compound 3 lay 23.5 percentage points below the measured number; the measured number lies above the stated range.
By their numbers in this assay, from the lowest: compound 2; then compound 1; then compound 3.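

In this assay, the group on an oxygen next to a carbonyl group can do more than lower the number: cyclopropyl gives a number 32.1 percentage points higher from compound 2 to compound 3 (beyond the scatter) and also a number 17 percentage points higher from compound 1 to compound 3 (beyond the scatter) in this series. Among these three compounds, the ring-bearing compound 3 therefore stands above both open-chain compounds, with each step beyond the scatter. No available evidence explains this order.

Going by these compounds, whether cyclobutyl on the same oxygen would follow cyclopropyl remains open. So does whether a longer chain carrying an amine would fit this order.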